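Side-chain benzoyloxy to trifluoroacetamide: solubility outlook

The source may report more compounds than this note shows. Statements on the series, on what has been measured and on what is new or still open speak of the compounds shown alone.

Compound 1 `O=C(OC[C@H]1CN(c2ccc(-n3cc(-c4ccccn4)cn3)c(F)c2)C(=O)O1)c1ccccc1` carries a benzoyloxy group on a saturated chain carbon bound to a saturated ring carbon. In a physicochemical assay for solubility, read by HPLC, with a stated time of 24 h (on this read-out higher numbers stand for higher solubility and lower numbers for lower solubility), compound 1 gives <= 65400 nM, which is a limit of the assay rather than a number. Compound 2 `CN(C)S(=O)(=O)NC[C@H]1CN(c2ccc(-n3cc(-c4ccccn4)cn3)c(F)c2)C(=O)O1` gives 472000 nM in this assay, and compound 3 `CCNC(=O)NC[C@H]1CN(c2ccc(-n3cc(-c4ccccn4)cn3)c(F)c2)C(=O)O1` gives 222000 nM. Both measured steps away from compound 1 exchange the benzoyloxy group for a nitrogen-linked substituent: an at least 7.2-fold higher number from compound 1 to compound 2 (0.85 log units; beyond the scatter), and an at least 3.3-fold higher number from compound 1 to compound 3 (0.53 log units; beyond the scatter). Between the two replacements themselves, a 2.1-fold lower number from compound 2 to compound 3 (0.33 log units; beyond the scatter). The position of compound 1 rests on (the limit of <= 65400 nM in this assay, at which 1 of the 3 values shown sits), so the measured steps from it are known only as minimum sizes.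

Compound 4 `O=C1O[C@@H](CNC(=O)C(F)(F)F)CN1c1ccc(-n2cc(-c3ccccn3)cn2)c(F)c1` is the next variation at the same position. ((trifluoromethyl)carbonyl)amino in place of benzoyloxy on a saturated chain carbon bound to a saturated ring carbon The two measured steps from compound 1 both run toward higher solubility once the benzoyloxy group is removed, and the same direction is expected for compound 4, with the incoming group lacking any ring. The expected step is an at least 2.2-fold higher number from compound 1 to compound 4 (0.36 log units; beyond the scatter), likely smaller than the move to compound 2. Compound 4 is therefore estimated at 150000 nM, within a range from 60000 nM to 400000 nM.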

Compound 4, solubility: 114000 nM
Compound 4: middle estimate off by 1.3-fold (0.12 log units), on the high side; measured number inside the range.
By their numbers in this assay, from the lowest: compounds 4 and 3 (each within the scatter of the next); then compound 2. At a limit, below all of these: compound 1.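

Unlike the replacements in compounds 2 and 3, the ((trifluoromethyl)carbonyl)amino group leaves a floor that does not clear the scatter: an at least 1.7-fold higher number from compound 1 to compound 4 (0.24 log units; that floor lies within the scatter). From the compounds shown here alone, compound 1 stands at a limit of the assay, so the true size of that step remains unknown: the limit of <= 65400 nM in this assay, at which 1 of the 4 values shown sits. On the amine nitrogen, ethylcarbamoyl and (trifluoromethyl)carbonyl cannot be separated in this assay, with a 1.9-fold lower number from compound 3 to compound 4 (0.29 log units; within the scatter), whereas the exchange of dimethylsulfamoyl for (trifluoromethyl)carbonyl clears the scatter, with a 4.1-fold lower number from compound 2 to compound 4 (0.62 log units; beyond the scatter).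

The compounds shown leave open what a free amine or a carboxylic acid would give on the saturated chain carbon bound to a saturated ring carbon in place of these nitrogen-linked groups. Also open, going by these compounds, is whether the separation of the dimethylsulfamoyl compound from the two carbonyl-linked compounds would persist with a longer chain on the sulfamoyl nitrogen, or whether it belongs to the dimethyl group alone.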